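This account rests on a few compounds, and the source may have more. Where it says the series, first, only, none or still open, it means among the compounds named here.

In a functional assay on lung (Cavia porcellus) for binding affinity to cysteinyl leukotriene receptor (Homo sapiens) (on this read-out higher numbers stand for weaker inhibition and lower numbers for stronger inhibition), compound 2 `COC(=O)COc1cccc(/C=C/c2ccc3ccccc3n2)c1` gives 1000 nM, and compound 1 `CCCCSc1ccc2ccc(/C=C/c3cccc(OCC(=O)OC)c3)nc2c1` gives 1500 nM; the step of a 1.5-fold lower number from compound 1 to compound 2 (0.18 log units; within the scatter) lies within the scatter, so the two measured numbers do not separate. Compound 3 `CCOC(=O)CCCOc1cccc(/C=C/c2ccc3ccccc3n2)c1` differs from compound 2 by 2-(ethoxycarbonyl)ethyl in place of methoxycarbonyl on a saturated chain carbon bound to an oxygen on an aromatic ring. For the measured compounds named here, no measured step touches this part of the molecule: the only known step, a 1.5-fold lower number from compound 1 to compound 2 (0.18 log units; within the scatter), concerns another position and offers no guide to direction. Compound 3 is therefore expected to show no step beyond the scatter, no change at the digits printed from compound 2 to compound 3 (within the scatter). The estimate for compound 3 is 1000 nM, with a range from 300 nM to 3500 nM.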

Compound 3, half-maximal inhibitory concentration: 580 nM
Compound 3: the middle estimate sits 1.7-fold (0.24 log units) above what was measured, and the stated range covers the measured number.
By their numbers in this assay, from the lowest: compounds 3, 2 and 1 (each within the scatter of the next, the first and the last beyond it).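

Read at this position for the first time, the change from (methoxycarbonyl)methoxy to 3-(ethoxycarbonyl)propoxy gives a 1.7-fold lower number from compound 2 to compound 3 (0.24 log units; within the scatter) in this assay. The larger ester chain of compound 3 therefore does not separate from the shorter one of compound 2, so this position accepts the exchange without a step beyond the scatter. Nothing available bears on this result. From the compounds shown here alone, whether a free carboxylic acid in place of the ester, or an amine at the chain end, would give a step beyond the scatter remains open. So does the reading for a still longer chain.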